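The compounds below may be only part of what the source reports. "The series", "measured", "known", "first", "only" and "open" are said of these compounds alone.

Measured in a functional assay on CCRF-CEM cells (Homo sapiens), read by MTT assay, with a stated time of 72 h; on this read-out higher numbers stand for weaker inhibition and lower numbers for stronger inhibition:
- compound 1 `C#Cc1cn([C@@H]2O[C@H](CO)[C@@H](O)[C@H]2O)c2ncnc(SC)c12`: > 20000 nM (a limit)
- compound 2 `C#Cc1cn([C@@H]2O[C@H](CO)[C@@H](O)[C@H]2O)c2ncnc(NC)c12`: > 20000 nM (a limit)
- compound 3 `CN(C)c1ncnc2c1c(-c1cc3ccccc3o1)cn2[C@@H]1O[C@H](CO)[C@@H](O)[C@H]1O`: > 20000 nM (a limit)

Compound 3 stands at > 20000 nM, which is a limit of the assay and not a number. The same holds across the series, as shown by the limit of > 20000 nM in this assay, at which 3 of the 3 values shown sit. The next compound is compound 4 `C#Cc1cn([C@@H]2O[C@H](CO)[C@@H](O)[C@H]2O)c2ncnc(N(C)C)c12`, and its difference from compound 3 is ethynyl in place of 1-benzofuran-2-yl on an aromatic carbon. In words, ethynyl takes the place of 1-benzofuran-2-yl on an aromatic carbon.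

For the measured compounds named here, the one measured step is a step that the two limits leave unreadable from compound 1 to compound 2, so it offers no size to carry over. Compound 1 already bears ethynyl and gives > 20000 nM, a limit. Compound 2 also bears ethynyl and gives > 20000 nM, again a limit. No step beyond the scatter is therefore expected in this assay, and the result will probably be only a limit once more.

The expected step is a number no higher from compound 3 to compound 4 (the limit leaves the size open). The estimate for compound 4 is 20000 nM, with an expected range of 7000 nM to 50000 nM.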

Compound 4, half-maximal inhibitory concentration: 90 nM
Compound 4: the middle estimate sits 220-fold (2.35 log units) above what was measured; measured number outside the range, below it.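

In this assay, ethynyl on this aromatic carbon of the five-membered aromatic ring can go with clear activity, as replacing 1-benzofuran-2-yl gives an at least 220-fold lower number from compound 3 to compound 4 (2.34 log units; beyond the scatter). Ethynyl alone is not enough, however: one added methyl on the nitrogen gives an at least 220-fold lower number from compound 2 to compound 4 (2.34 log units; beyond the scatter), and dimethylamino in place of methylsulfanyl gives an at least 220-fold lower number from compound 1 to compound 4 (2.34 log units; beyond the scatter). Among these four compounds, a measurable value appears only where ethynyl and dimethylamino stand together, and compound 1, compound 2 and compound 3 each lack one of the two.

On these data alone, the true size of these steps stays open, as the other three compounds give only a limit of the assay: the limit of > 20000 nM in this assay, at which 3 of the 4 values shown sit. Also open, as far as these compounds go, is whether ethyl groups on that nitrogen, or a longer alkyne chain in place of ethynyl, would keep this activity.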